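Fluoro in place of hydrogen on the phenyl of compound 1

The source may hold more compounds than are shown below. What is called first, only, known or untested is meant among the compounds shown, and "the series" means these compounds.

Measured so far:
compound 1 `COc1cc(OC)cc(-n2c(-c3ccccc3)nc(C)c2C)c1` — 59%
compound 2 `COc1ccc(-n2c(-c3ccc(F)cc3)nc(C)c2C)cc1` — 45.7%

In a functional assay, with a stated time of 15 min, tested at 80 uM (a lower number here means a weaker effect, a higher number a stronger effect of the compound at the concentration tested), compound 1 gives 59%, the higher of the two numbers shown; compound 2 gives 45.7%, a gap beyond the usual scatter. Compound 3 `COc1cc(OC)cc(-n2c(-c3ccc(F)cc3)nc(C)c2C)c1` differs from compound 1 in one place: fluoro in place of hydrogen on an aromatic carbon. Within the data shown here, no pair of measured compounds isolates this change, so no step size is known. Compound 3 is expected to stay close to compound 1, with a step of a number 7 percentage points lower from compound 1 to compound 3 (within the scatter) that may fall within the scatter. The estimate for compound 3 is 52%, with a range from 35% to 70%.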

Compound 3, a percentage reported as activity, at one concentration (the size of the read-out at that concentration, not a potency): 58.1%
Estimate against measurement, compound 3: 6.1 percentage points below; the range from low to high includes it.
By their numbers in this assay, from the lowest: compound 2; then compounds 3 and 1 (each within the scatter of the next).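

In this assay, among these compounds, the change from phenyl to 4-fluorophenyl gives a number 0.9 percentage points lower from compound 1 to compound 3 (within the scatter), the first direct reading of this change. At this position on the core of compound 1, fluoro and hydrogen therefore cannot be told apart in this read-out at the single concentration tested. No measurement on hand offers an explanation for this result.

The compounds shown leave open whether an amine, a carboxylic acid or a longer chain at this same position would give a step beyond the scatter. They also leave open whether fluoro would behave the same way on another ring carbon.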